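Dichloro to Difluoro at the Aryl Ketone

The compounds below may be only part of what the source reports. "The series", "measured", "known", "first", "only" and "open" are said of these compounds alone.

Compound 1 `COc1ccc(-c2cc(/C=C/C(=O)c3ccc(OC)c(OC)c3)[nH]n2)cc1` gives 1760 nM in a functional assay on MCF7 cells (Homo sapiens) for inhibition, read by sulforhodamine B assay, with a stated time of 48 h; on this read-out higher numbers stand for weaker inhibition of growth and lower numbers for stronger inhibition of growth. Compound 2 `COc1cc(-c2cc(/C=C/C(=O)c3ccc(Cl)c(Cl)c3)[nH]n2)cc(OC)c1OC` reaches only the limit of this assay, > 100000 nM, so it stands at the limit of > 100000 nM in this assay, at which 1 of the 2 values shown sits, and its true position is not known. Compound 3 `COc1cc(-c2cc(/C=C/C(=O)c3ccc(F)c(F)c3)[nH]n2)cc(OC)c1OC` differs from compound 2 by 3,4-difluorophenyl in place of 3,4-dichlorophenyl on a carbonyl carbon. For the measured compounds named here, no measured pair tells what this exchange does here, so no step beyond the scatter is expected, and compound 3 is estimated at 70000 nM, from 15000 nM to 100000 nM, which would mean a step of an at least 1.4-fold lower number from compound 2 to compound 3 (0.15 log units; that floor lies within the scatter).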

Compound 3, concentration for total growth inhibition: 12300 nM
Estimate against measurement, compound 3: 5.7-fold (0.76 log units) above; measured number outside the range, below it.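

With compound 3, this place on a carbonyl carbon proves sensitive to the exchange: 3,4-difluorophenyl in place of 3,4-dichlorophenyl gives an at least 8.1-fold lower number from compound 2 to compound 3 (0.91 log units; beyond the scatter) in this assay. For the compounds shown here, this is the first single-place comparison, and it shows that growth inhibition can be recovered at this position without changing the rest of the molecule. The true size of the step stays unknown, since one end is a limit: the limit of > 100000 nM in this assay, at which 1 of the 3 values shown sits.

The compounds shown leave open how an unsubstituted phenyl, or a phenyl carrying an amine or a nitrile, would read at this place. They also leave open whether the same exchange would act alike on the core of compound 1.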